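The source may report more compounds than this note shows. Statements on the series, on what has been measured and on what is new or still open speak of the compounds shown alone.

Measured so far in a functional assay on HL-60 cells (Homo sapiens) for antiproliferative activity, read by MTT assay, with a stated time of 72 h; on this read-out lower numbers stand for stronger inhibition and higher numbers for weaker inhibition:
- compound 1 `CCn1cc(C(=O)O)c(=O)c2cc(F)c(N3CCN(C(=N)NS(=O)(=O)c4ccc(C(F)(F)F)cc4)CC3)cc21`: 43 nM
- compound 2 `CCn1cc(C(=O)O)c(=O)c2cc(F)c(N3CCN(C(=N)NS(=O)(=O)c4cccc(Cl)c4)CC3)cc21`: 43 nM
- compound 3 `CCn1cc(C(=O)O)c(=O)c2cc(F)c(N3CCN(C(=N)NS(=O)(=O)c4ccccc4)CC3)cc21`: 43 nM

Compound 3 stands level with compound 1 and compound 2 at the digits shown. Compound 4 `CCn1cc(C(=O)O)c(=O)c2cc(F)c(N3CCN(C(=N)NS(=O)(=O)c4ccccc4C(F)(F)F)CC3)cc21` has trifluoromethyl in place of hydrogen on an aromatic carbon, ortho to a large group: trifluoromethyl in place of hydrogen on an aromatic carbon. Among the compounds with values here, the steps that bear on this are no change at the digits printed from compound 1 to compound 3 (within the scatter) and no change at the digits printed from compound 2 to compound 3 (within the scatter), along with no change at the digits printed from compound 1 to compound 2 (within the scatter). All three lie within the scatter. Within the data shown here, no measured compound carries a group at this place, so the evidence is indirect. In this assay, no step beyond the scatter is expected, and the estimated step is no change at the digits printed from compound 3 to compound 4 (within the scatter). The estimate for compound 4 is 43 nM, with an expected range of 20 nM to 95 nM.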

Compound 4, half-maximal inhibitory concentration: 43 nM
Compound 4: middle estimate and measured number agree at the digits printed; the range from low to high includes it.
By their numbers in this assay, from the lowest: compounds 1, 2, 3 and 4 (each within the scatter of the next).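

In this assay a group now stands at this place, trifluoromethyl on an aromatic carbon ortho to a large group, and the result is no change at the digits printed from compound 3 to compound 4 (within the scatter). The 2-(trifluoromethyl)phenyl group also shows no change at the digits printed from compound 1 to compound 4 (within the scatter) against 4-(trifluoromethyl)phenyl and no change at the digits printed from compound 2 to compound 4 (within the scatter) against 3-chlorophenyl, so this place takes trifluoromethyl without a step beyond the scatter. No available evidence accounts for this flat result.

The compounds shown leave open whether any group at this place can move the read-out. Going by these compounds, the effect of an amine or a carboxylic acid here remains unknown.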